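Bromine to Two Methyls: Expecting Little Change

This account rests on a few compounds, and the source may have more. Where it says the series, first, only, none or still open, it means among the compounds named here.

Compound 1 `O=C1C=CC2(C=C1)OCCC(=O)N2c1ccccc1` is the parent of this small series. In a functional assay on BV-2 cells (Mus musculus), read by Griess assay, with a stated time of 24 h (on this read-out higher numbers stand for weaker inhibition and lower numbers for stronger inhibition), compound 1 gives 1300 nM. Compound 2 `O=C1C=CC2(C=C1)OCC(Cc1ccc(Br)cc1)C(=O)N2c1ccccc1` carries 4-bromobenzyl in place of hydrogen on a saturated ring carbon; in this assay compound 2 gives 1380 nM. The step of a 1.1-fold higher number from compound 1 to compound 2 (0.03 log units; within the scatter) shows that adding this group left the read-out essentially where it was. Of the two numbers shown, compound 2 holds the higher one, but its gap to compound 1 lies within the scatter, so neither compound can be called the stronger or weaker inhibitor.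

Within the data shown here, compound 3 `Cc1cc(C)cc(CC2COC3(C=CC(=O)C=C3)N(c3ccccc3)C2=O)c1` is the next step. 3,5-dimethylphenyl in place of 4-bromophenyl on a saturated chain carbon bound to a saturated ring carbon The only measured step that touches this part of the structure is the one from compound 1 to compound 2, and it lay within the scatter; no measured step compares one aryl group with another at this place. The most reasonable expectation is therefore that this swap also changes little. For compound 3 the estimated step is a 1.0-fold higher number from compound 2 to compound 3 (0.01 log units; within the scatter). Compound 3 is expected to give 1400 nM in this assay, with a range from 600 nM to 3300 nM.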

Compound 3, half-maximal inhibitory concentration: 1820 nM
Compound 3: the middle estimate sits 1.3-fold (0.11 log units) below what was measured, within the range that was stated.
By their numbers in this assay, from the lowest: compounds 1, 2 and 3 (each within the scatter of the next).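

Among these compounds, this is the first comparison of one aryl group with another on a saturated chain carbon bound to a saturated ring carbon: going from 4-bromophenyl to 3,5-dimethylphenyl gives a 1.3-fold higher number from compound 2 to compound 3 (0.12 log units; within the scatter) in this assay, so the read-out does not separate these two groups. Set against the unsubstituted parent, the 3,5-dimethylbenzyl group gives a 1.4-fold higher number from compound 1 to compound 3 (0.15 log units; within the scatter), which means that two different benzyl groups now stand within the scatter of plain hydrogen on the saturated ring carbon, and the parent and both of its benzyl relatives cannot be ranked. No measurement is available that could explain why these numbers sit so close together.

The compounds shown leave open whether a group of another kind on this phenyl ring, such as a carboxylic acid or an amine, would give a step beyond the scatter. They also leave open what a longer chain carrying the phenyl ring would do, or whether a small group such as methyl or a hydroxyl in place of the whole benzyl group would read any differently.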